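Urea series: swapping the aryl amine on compound 1

The source may hold more compounds than are shown below. What is called first, only, known or untested is meant among the compounds shown, and "the series" means these compounds.

Measured so far:
compound 1 `COc1ccc(F)cc1Nc1cc(NC(=O)Nc2c(Cl)cccc2Cl)ncn1` — 31.3%
compound 2 `COc1cc(NC(=O)Nc2cc(Nc3ccc(C)c(C)c3)ncn2)cc(OC)c1` — 45.3%
compound 3 `COc1cc(NC(=O)Nc2cc(Nc3cc(F)ccc3OC)ncn2)cc(OC)c1` — 37.7%

All three were run in a functional assay on NCI-H226 cells (Homo sapiens) for inhibition, read by MTT assay, with a stated time of 48 h, tested at 10 uM; a lower number here means less inhibition, a higher number more inhibition at the concentration tested (going by the name of the read-out). Compound 1 gives the lowest of the three numbers; its nearest neighbour is compound 3, a step that is a number 6.4 percentage points higher from compound 1 to compound 3 (within the scatter), and the gap to compound 2 is beyond the scatter.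

The new compound is compound 4 `COc1ccc(Nc2cc(NC(=O)Nc3c(Cl)cccc3Cl)ncn2)cc1C`, not yet measured in this assay. It differs from compound 1 in one place:
4-methoxy-3-methylphenyl in place of 5-fluoro-2-methoxyphenyl on a nitrogen on an aromatic ring

The change sits on the aryl amine side of the shared core, which is the side varied in the step from compound 2 to compound 3, where a number 7.6 percentage points lower from compound 2 to compound 3 (within the scatter). That step ran in the opposite sense, putting the 5-fluoro-2-methoxyphenyl group in, and it stayed within the scatter. Within the data shown here, no measured pair shows 4-methoxy-3-methylphenyl itself. Among the measured compounds shown here, the only step on this side therefore suggests a small shift, if any, toward higher inhibition when the 5-fluoro-2-methoxyphenyl group is removed. The expected step is a number 5.7 percentage points higher from compound 1 to compound 4 (within the scatter), not clearly beyond the scatter. For compound 4 the estimated value in this assay is 37%, with a range of 24% to 50%.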

Compound 4, a percentage reported as inhibition, at one concentration (the size of the read-out at that concentration, not a potency): 50%
Compound 4: middle estimate off by 13 percentage points, on the low side, within the range that was stated.
By their numbers in this assay, from the lowest: compounds 1, 3, 2 and 4 (each within the scatter of the next, the first and the last beyond it).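

Notes on the aryl amine position: in this assay this side of the shared core now gives its first step beyond the scatter, a number 18.7 percentage points higher from compound 1 to compound 4 (beyond the scatter), whereas the only earlier step on this side, a number 7.6 percentage points lower from compound 2 to compound 3 (within the scatter), stayed within it. So the group on this nitrogen can move the read-out at the concentration tested, at least with the 2,6-dichlorophenyl urea partner held constant. The groups 5-fluoro-2-methoxyphenyl and 4-methoxy-3-methylphenyl match in heavy-atom count, hydrogen-bond donors and acceptors, and net charge, and nothing available accounts for the size of this step.

This single step cannot show whether 4-methoxy-3-methylphenyl would give a similar step with the 3,5-dimethoxyphenyl partner on the urea, or whether the methyl group or the placement of the methoxy group goes with the higher number. Also open, on these data alone, is how this position would read with a ring carrying a dimethylamino group or a carboxylic acid in place of the methyl group.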